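The source may report more compounds than this note shows. Statements on the series, on what has been measured and on what is new or still open speak of the compounds shown alone.

Measured compounds in a functional assay on LNCaP cells (Homo sapiens) for cytotoxicity, read by MTT assay, with a stated time of 72 h; on this read-out lower numbers stand for stronger inhibition and higher numbers for weaker inhibition:
- compound 1, `COC(=O)CNc1c(C(=O)NCc2ccc(F)cc2)nc(Br)c2cccnc12`, gives 5000 nM.
- compound 2, `O=C(NCCCNc1c(C(=O)NCc2ccc(F)cc2)nc(Br)c2cccnc12)c1ccccc1`, gives only a limit of the assay, > 10000 nM.
- compound 3, `N[C@H]1CC[C@H](Nc2c(C(=O)NCc3ccc(F)cc3)nc(N3CCCCS3(=O)=O)c3cccnc23)CC1`, gives 8000 nM.

Compound 2 therefore stands at the limit (the limit of > 10000 nM in this assay, at which 1 of the 3 values shown sits); its true figure is not known, only that it sits at or past that ceiling. Among the compounds with values here, the one step that touches it, an at least 2.0-fold higher number from compound 1 to compound 2 (0.30 log units; that floor lies within the scatter), is reported at its floor, which lies within scatter, so compound 2 is not separated from compound 1 with confidence.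

Compound 4, `CN(C)CCCNc1c(C(=O)NCc2ccc(F)cc2)nc(Br)c2cccnc12`, is the next compound in the series. Its change from compound 2 reads (dimethylamino in place of benzamido on a saturated chain carbon, three bonds along the chain from a nitrogen on an aromatic ring). Within the data shown here, the only measured step that bears on this chain substituent is an at least 2.0-fold higher number from compound 1 to compound 2 (0.30 log units; that floor lies within the scatter), where the 2-benzamidoethyl replaced a methoxycarbonyl; compound 4 removes the benzamido again while keeping the chain. Taking that step as the nearest guide, a return toward the number of compound 1 is the expectation, with the sign of an at least 1.2-fold lower number from compound 2 to compound 4 (0.09 log units; that floor lies within the scatter) pointing to a lower number, though a result that again sits at the limit remains quite possible. Compound 4 is thus expected to give about 8000 nM in this assay, within the range 3000 nM to 20000 nM.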

Compound 4, half-maximal inhibitory concentration: 8000 nM
Compound 4: middle estimate and measured number agree at the digits printed; the measured number falls inside the stated range.
By their numbers in this assay, from the lowest: compounds 1, 3 and 4 (each within the scatter of the next). At a limit, above all of these: compound 2.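

In this assay compound 4 gives 8000 nM, so the chain that ends in a 2-(dimethylamino)ethyl group yields a measured number on the shared core, whereas the 2-benzamidoethyl group of compound 2 does not. Against the methoxycarbonyl group of compound 1, the change reads a 1.6-fold higher number from compound 1 to compound 4 (0.20 log units; within the scatter), so these two groups are not separated in this assay. The change from benzamido to dimethylamino reads an at least 1.2-fold lower number from compound 2 to compound 4 (0.09 log units; that floor lies within the scatter), which is only a floor, and the true size of this step is unknown: the limit of > 10000 nM in this assay, at which 1 of the 4 values shown sits.

From the compounds shown here alone, it remains open whether a primary amine or a carboxylic acid at the end of this chain, a morpholine in place of dimethylamino, or a longer chain would give a number separated from those of compound 1 and compound 4. Going by these compounds, it is also open whether any group at this position can move the number beyond the scatter, as neither step with compound 4 shows such a move.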